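The compounds below may be only part of what the source reports. "The series", "measured", "known", "first", "only" and "open" are said of these compounds alone.

Working notes on the series.

Of the compounds shown here, two have numbers so far. Compound 1 `COc1cc(/C=C/C(=O)Nc2ccccc2)ccc1OCCCCN1CCCCC1` gives, in a physicochemical assay for lipophilicity, using the shake flask method, measured as octanol-water partition, at pH 7.4 (a lower number here means a more polar compound, a higher number a more lipophilic compound), 1.61. Compound 2 `COc1cc(/C=C/C(=O)Nc2ccccc2)ccc1OCCCCN1CCCC1` gives in this assay 1.6; among the two numbers it stands lowest, with compound 1 its nearest neighbour, although the step of a number 0.01 log units lower from compound 1 to compound 2 (within the scatter) is within the scatter. The ring swap alone therefore left the partition coefficient essentially unchanged.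

Compound 3 `COc1cc(/C=C/C(=O)Nc2ccccc2)ccc1OCCCCCN1CCCCC1` is not yet measured. Its difference from compound 2 reads ((piperidin-1-yl)methyl in place of pyrrolidin-1-yl on a saturated chain carbon, four bonds along the chain from an oxygen on an aromatic ring). Within the data shown here, only one measured step bears on it, a number 0.01 log units lower from compound 1 to compound 2 (within the scatter), which covers the ring swap in the opposite direction and was flat; the additional chain carbon has no measured counterpart in this set. The expected change is a small rise, a number 0.40 log units higher from compound 2 to compound 3 (beyond the scatter), near the edge of the scatter. Compound 3 is expected to give in this assay about 2, estimated to fall between 1.6 and 2.4.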

Compound 3, partition coefficient: 1.65
The estimate for compound 3 lay 0.35 log units above the measured number; the range from low to high includes it.
By their numbers in this assay, from the lowest: compounds 2, 1 and 3 (each within the scatter of the next).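

Working from this place, on a saturated chain carbon, four bonds along the chain from an oxygen on an aromatic ring, (piperidin-1-yl)methyl in place of piperidin-1-yl now has a measured step of its own in this assay: a number 0.04 log units higher from compound 1 to compound 3 (within the scatter). With pyrrolidin-1-yl as the group that leaves, the same place gives a number 0.05 log units higher from compound 2 to compound 3 (within the scatter), so neither step separates these compounds in this assay. Among these compounds, nothing measured so far offers an explanation for how close these three compounds lie.

Still open, as far as these compounds go, is whether (pyrrolidin-1-yl)methyl at this place would also stay within the scatter of compound 2 and compound 3. Equally open, from the compounds shown here alone, is whether a morpholin-4-yl or dimethylamino group, or a chain longer than that of compound 3, would give a step beyond the scatter.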